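The source may report more compounds than this note shows. Statements on the series, on what has been measured and on what is new or still open speak of the compounds shown alone.

Within the data shown here, in a functional assay on HeLa cells (Homo sapiens) for cytotoxicity, read by MTT assay, with a stated time of 3 days (on this read-out lower numbers stand for stronger inhibition and higher numbers for weaker inhibition), two compounds sharing one core have numbers so far. Compound 1 `C[C@H]1O[C@@H](n2cc(F)c(NC(=O)Oc3ccc(Cl)cc3)nc2=O)[C@H](O)[C@@H]1O` gives 30 ug/mL, and compound 2 `CCC(C)COC(=O)Nc1nc(=O)n([C@@H]2O[C@H](C)[C@@H](O)[C@H]2O)cc1F` gives 90 ug/mL, the higher of the two and so the weaker result. The next compound, compound 3 `CC(C)CCOC(=O)Nc1nc(=O)n([C@@H]2O[C@H](C)[C@@H](O)[C@H]2O)cc1F`, differs from compound 2 only in how the same atoms of one chain are joined: isobutyl in place of sec-butyl on a saturated chain carbon bound to an oxygen next to a carbonyl group. Cut one bond further out, this reads 2-methylbutyl to isopentyl. Among the measured compounds shown here, the only measured step, a 3.0-fold higher number from compound 1 to compound 2 (0.48 log units; beyond the scatter), is modest and swaps 4-chlorophenyl for 2-methylbutyl, so it has a ring leaving, whereas no ring is involved here. For the measured compounds named here, no measured step covers an exchange between two such chains, which leaves only indirect guidance. The expected change is a 1.1-fold lower number from compound 2 to compound 3 (0.05 log units; within the scatter), with nothing expected beyond the scatter. The estimated value for compound 3 is 80 ug/mL, within an expected range from 35 ug/mL to 180 ug/mL.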

Compound 3, half-maximal inhibitory concentration: 90 ug/mL
Compound 3: middle estimate off by 1.1-fold (0.05 log units), on the low side, and the stated range covers the measured number.
By their numbers in this assay, from the lowest: compound 1; then compounds 2 and 3 (each within the scatter of the next).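

In this assay, isobutyl in place of sec-butyl on a saturated chain carbon bound to an oxygen next to a carbonyl group gives no change at the digits printed from compound 2 to compound 3 (within the scatter), so this rearrangement of the same atoms within the chain leaves the read-out unmoved. Isopentyl in place of 4-chlorophenyl gives a 3.0-fold higher number from compound 1 to compound 3 (0.48 log units; beyond the scatter), which shows that the earlier step away from the ring is not tied to one particular chain. No measured property of these groups is available to account for either result.

As far as these compounds go, whether an unbranched pentyl chain or a longer chain such as octyl would shift the number remains open. So does the part played by the chlorine, which a plain phenyl group in the same place could help to separate from that of the ring.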